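The source may hold more compounds than are shown below. What is called first, only, known or untested is meant among the compounds shown, and "the series" means these compounds.

Measured so far:
compound 1, `Cn1ccc2ccc(-c3cc(Nc4ccccc4S(N)(=O)=O)cc4nccnc34)cc21`: 6 ug/mL
compound 2, `Cn1ccc2ccc(-c3cc(Nc4cnccc4C(=O)NCc4cncnc4)cc4nccnc34)cc21`: 233 ug/mL

In a physicochemical assay for solubility, read by spectrophotometry, measured as kinetic solubility, at pH 8, tested at 500 uM (a lower number here means a less soluble compound, a higher number a more soluble compound), compound 2 gives 233 ug/mL, the higher of the two numbers recorded, and compound 1 gives 6 ug/mL. Compound 3, `CN1CC(NC(=O)c2ccncc2Nc2cc(-c3ccc4ccn(C)c4c3)c3nccnc3c2)C1`, has not yet been tested in this assay. It differs from compound 2 in one place: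

1-methylazetidin-3-yl in place of (pyrimidin-5-yl)methyl on an amide-type nitrogen

Going by the values given here, no step between two measured compounds exists that matches this change, so nothing here sets its size. Compound 3 is expected to stay close to compound 2, with a step of a 1.2-fold lower number from compound 2 to compound 3 (0.07 log units; within the scatter), within the scatter. Compound 3 is estimated at 200 ug/mL, with a range from 100 ug/mL to 240 ug/mL.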

Compound 3, solubility: 170 ug/mL
Compound 3: middle estimate off by 1.2-fold (0.07 log units), on the high side; low and high end bracket the measured number.
By their numbers in this assay, from the lowest: compound 1; then compounds 3 and 2 (each within the scatter of the next).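

In this assay the step on the amide-type nitrogen, a 1.4-fold lower number from compound 2 to compound 3 (0.14 log units; within the scatter), shows that this position accepts 1-methylazetidin-3-yl in place of (pyrimidin-5-yl)methyl with no change beyond the scatter. A four-membered non-aromatic ring thus reads the same here as a six-membered aromatic ring on a methyl link, though this rests on one pair only. Nothing measured here accounts for this result. The compounds shown leave open how an open-chain amine or a carboxylic acid on this nitrogen would read. They also leave open whether a simple methyl group there would stay level with compound 2.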